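Swapping Pyrimidine for Pyrazine on a Shared Core

This account rests on a few compounds, and the source may have more. Where it says the series, first, only, none or still open, it means among the compounds named here.

Within the data shown here, compound 2 `Fc1ccc2nc(-c3cncnc3)n(C3CC3)c2c1` gives 40 nM in an assay on cells for inhibition of cytochrome P450 11B2, mitochondrial (Homo sapiens), read by HPLC, with a stated time of 90 min (on this read-out lower numbers stand for stronger inhibition and higher numbers for weaker inhibition), the lowest of the two numbers so far; compound 1 `Fc1ccc2nc(-n3ccnn3)n(C3CC3)c2c1` gives 1060 nM, and the step of a 27-fold lower number from compound 1 to compound 2 (1.42 log units; beyond the scatter) lies beyond the scatter. Compound 3 `Fc1ccc2nc(-c3cnccn3)n(C3CC3)c2c1` differs from compound 2 by pyrazin-2-yl in place of pyrimidin-5-yl on an aromatic carbon. Among the measured compounds shown here, no measured step concerns this exchange; the single known step compared a triazole with a pyrimidine and cannot simply be carried over. A weaker number is nevertheless expected for compound 3, a 10-fold higher number from compound 2 to compound 3 (1.00 log units; beyond the scatter). Compound 3 is therefore estimated at 400 nM, within a range from 80 nM to 2500 nM.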

Compound 3, half-maximal inhibitory concentration: 541 nM
Beside the measured number, compound 3's estimate is 1.4-fold (0.13 log units) below it; measured number inside the range.
By their numbers in this assay, from the lowest: compound 2; then compounds 3 and 1 (each within the scatter of the next).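

Exchanging pyrimidin-5-yl for pyrazin-2-yl gives a 14-fold higher number from compound 2 to compound 3 (1.13 log units; beyond the scatter) even though the two groups have the same atoms joined differently, so at this position this assay responds to how the ring is put together and not only to its atom count. The other step, a 2.0-fold lower number from compound 1 to compound 3 (0.29 log units; within the scatter), leaves pyrazin-2-yl and 1H-1,2,3-triazol-1-yl indistinguishable, and pyrimidin-5-yl alone stands apart among the three groups. Nothing available accounts for the gap between the two rings.

The compounds shown leave open how pyridin-3-yl would compare at this position, and whether an amine on the pyrimidin-5-yl ring would preserve the number of compound 2.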